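The compounds below may be only part of what the source reports. "The series", "measured", "known", "first", "only" and "open" are said of these compounds alone.

The measured compounds:

- compound 1, `CC[C@@H](Nc1c(C#N)c(-c2ccc(Br)cc2)nc2cnccc12)C(N)=O`, gives 2.2 in a physicochemical assay for lipophilicity, read by HPLC, at pH 7.5; a lower number here means a more polar compound, a higher number a more lipophilic compound
- compound 2, `CC[C@@H](Nc1c(C#N)c(-c2ccc(-c3ccncc3C)cc2)nc2cnccc12)C(N)=O`, gives 2 in this assay
- compound 3, `CC[C@@H](Nc1c(C#N)c(-c2ccc(-c3ccc(OC)cc3)cc2)nc2cnccc12)C(N)=O`, gives 2.7 in this assay

Compound 3 sits highest of the three numbers in this assay: the nearest is compound 1, with a number 0.50 log units higher from compound 1 to compound 3 (beyond the scatter), and the furthest is compound 2, with a number 0.70 log units higher from compound 2 to compound 3 (beyond the scatter). The step from compound 1 to compound 2, a number 0.20 log units lower from compound 1 to compound 2 (within the scatter), did not move the number beyond the scatter.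

Compound 4, `CC[C@@H](Nc1c(C#N)c(-c2ccc(-c3ccccc3F)cc2)nc2cnccc12)C(N)=O`, is not yet measured. It differs from compound 3 in one place: 2-fluorophenyl in place of 4-methoxyphenyl on an aromatic carbon. Among the measured compounds shown here, none of the measured steps exchanges one six-membered carbon ring for another, so no step speaks directly to this change. The two steps that bear on the leaving group, the ones from compound 1 to compound 3 and from compound 2 to compound 3, show that putting 4-methoxyphenyl onto this carbon raised the number by a modest amount; the entering 2-fluorophenyl is of similar size. On that basis a small step is expected, if anything a little upward, and it may well stay within the scatter. The estimated step is a number 0.20 log units higher from compound 3 to compound 4 (within the scatter). For compound 4 the estimate in this assay is 2.9, with a range from 2.4 to 3.4.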

Compound 4, distribution coefficient: 2.7
Beside the measured number, compound 4's estimate is 0.20 log units above it; measured number inside the range.
By their numbers in this assay, from the lowest: compounds 2 and 1 (each within the scatter of the next); then compounds 3 and 4 (each within the scatter of the next).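

Putting 2-fluorophenyl in place of 4-methoxyphenyl on this aromatic carbon, para to a large group, gives no change at the digits printed from compound 3 to compound 4 (within the scatter) in this assay, so these two carbon-only aromatic rings read alike here even though they carry different substituents and the leaving group has a hydrogen-bond acceptor that the entering group lacks. Compound 4 also repeats the gaps seen with compound 3, with a number 0.70 log units higher from compound 2 to compound 4 (beyond the scatter) and a number 0.50 log units higher from compound 1 to compound 4 (beyond the scatter), so those gaps to the 3-methylpyridin-4-yl and bromo compounds are not tied to 4-methoxyphenyl alone. No measurement available here explains why the numbers fall this way.

Because the substituent and its place on the ring differ together between these two compounds, the result cannot separate the two, and it cannot show whether each substituent counts for anything, which a plain phenyl group at the same carbon would help to settle. Also open is how a ring bearing a carboxylic acid or an aminomethyl group would read in this assay, since every group shown here is either bromo or an aromatic ring without such a function.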